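Hydroxy Enters the Oxygen-Bearing Ring of Compound 1

The compounds below may be only part of what the source reports. "The series", "measured", "known", "first", "only" and "open" are said of these compounds alone.

Compound 1 `O=c1cc(-c2ccc(O)c(O)c2)oc2cc(OCCO)ccc12` has been tested in a functional assay for inhibition, with Rattus norvegicus as the target, using microsomes (on this read-out higher numbers stand for weaker inhibition and lower numbers for stronger inhibition), where compound 1 gives 16400 nM. Related compounds with the same atoms joined differently have also been run: in this assay compound 2 `O=c1c(OCCO)c(-c2ccc(O)c(O)c2)oc2ccccc12` gives 600 nM, and compound 3 `O=c1c(OCCO)c(-c2ccc(O)c(O)c2)oc2cc(O)ccc12` gives 21700 nM. The difference between the core of compound 1 and the core of compound 2 is not broken down here. Compound 2 and compound 3 differ by hydroxy in place of hydrogen on an aromatic carbon and this change produced a 36-fold higher number from compound 2 to compound 3 (1.56 log units; beyond the scatter). The value of compound 1 lies close to that of compound 3, within the scatter, and far from that of compound 2, beyond it.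

The compound still to be measured is compound 4 `O=c1c(O)c(-c2ccc(O)c(O)c2)oc2cc(OCCO)ccc12`. It differs from compound 1 by hydroxy in place of hydrogen on an aromatic carbon. For the measured compounds named here, this is the same kind of change as the one between compound 2 and compound 3, not the same change: in compound 4 the hydroxy enters on a six-membered aromatic ring with oxygen, ortho to the 3,4-dihydroxyphenyl group and two atoms from the ring oxygen, whereas in compound 3 it entered on a ring of carbon only. Going by the values given here, the sole measured guide is a 36-fold higher number from compound 2 to compound 3 (1.56 log units; beyond the scatter), which was large, but the surroundings differ, so its size is not carried over directly. The estimated step from compound 1 to compound 4 is a 1.8-fold higher number from compound 1 to compound 4 (0.26 log units; within the scatter), a rise expected to be smaller than the measured one. In this assay compound 4 is therefore expected to give 30000 nM, with an estimated range from 8000 nM to 120000 nM.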

Compound 4, half-maximal inhibitory concentration: 13800 nM
Beside the measured number, compound 4's estimate is 2.2-fold (0.34 log units) above it; low and high end bracket the measured number.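

In this assay, hydroxy in place of hydrogen on an aromatic carbon gave a 1.2-fold lower number from compound 1 to compound 4 (0.07 log units; within the scatter), so on the core of compound 1 this change leaves the read-out indistinguishable from its starting value. Set beside the earlier step, the same kind of change did not keep its size from one core to the other: the same change on two cores in this assay, a 36-fold higher number (1.56 log units; beyond the scatter) from compound 2 to compound 3 and a 1.2-fold lower number (0.07 log units; within the scatter) from compound 1 to compound 4, 43-fold (1.63 log units) apart, beyond the scatter of two such steps This shows that, in this series, the size of the step seen on one core cannot simply be carried to another; it does not show what separates the two cases, for the hydroxy stands on a six-membered aromatic ring with oxygen in compound 4 and on a ring of carbon only in compound 3, the cores differ as well, and each case rests on a single pair.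

The compounds shown leave open whether the large step belongs to the ring that takes the hydroxy or to the rest of the core, which a hydroxy placed on the ring of carbon only in the core of compound 1 would help to settle. They also leave open how a methoxy, an amine or a carboxylic acid would behave at the place taken by the hydroxy in compound 4.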